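The source may report more compounds than this note shows. Statements on the series, on what has been measured and on what is new or still open speak of the compounds shown alone.

Measured compounds in this series:

compound 1, `CC(C(=O)NCc1ccc(C(F)(F)F)cc1N1CCC(Cc2ccccc2)CC1)c1ccc(NS(C)(=O)=O)c(F)c1`, 1.4 nM
compound 2, `COc1ccc(N2CCN(c3cc(C(F)(F)F)ccc3CNC(=O)C(C)c3ccc(NS(C)(=O)=O)c(F)c3)CC2)cc1`, 1.6 nM
compound 3, `CC(C)COc1cc(C(F)(F)F)ccc1CNC(=O)C(C)c1ccc(NS(C)(=O)=O)c(F)c1`, 0.8 nM

In an assay on CHO cells for antagonist activity at transient receptor potential cation channel subfamily V member 1 (Homo sapiens), read by FLIPR (a higher number here means a weaker inhibitor, a lower number a stronger inhibitor), compound 3 gives 0.8 nM, the lowest of the three numbers, but its gaps to compound 1 and to compound 2 both lie within the scatter, so the three compounds cannot be ordered against each other on these data. The shared core, with the amide, the trifluoromethyl group and the methanesulfonamide, is kept throughout; only the group on the aromatic carbon ortho to the large group and meta to the trifluoromethyl group changes from compound to compound.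

Compound 4, `CC(C(=O)NCc1ccc(C(F)(F)F)cc1-c1cccc(F)c1)c1ccc(NS(C)(=O)=O)c(F)c1`, is the next step from compound 3. The change is 3-fluorophenyl in place of isobutoxy on an aromatic carbon. Going by the values given here, no comparable step between measured compounds is available here. Compound 1 and compound 2 carry larger ring-containing groups at the same position and sit within the scatter of compound 3, so a six-membered aromatic ring in place of isobutoxy is expected to leave the number close to where it is: the step of a 1.9-fold higher number from compound 3 to compound 4 (0.27 log units; within the scatter) is expected to stay within the scatter, with no clear direction. Compound 4 is therefore estimated at 1.5 nM in this assay, within 0.5 nM to 5 nM.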

Compound 4, inhibition constant: 1.9 nM
Compound 4: middle estimate off by 1.3-fold (0.10 log units), on the low side; measured number inside the range.
By their numbers in this assay, from the lowest: compounds 3, 1, 2 and 4 (each within the scatter of the next, the first and the last beyond it).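

In this assay, going by these compounds alone, a 2.4-fold higher number from compound 3 to compound 4 (0.38 log units; beyond the scatter) is the one step at this position that is printed as beyond the scatter, and it is modest in size. On this aromatic carbon, ortho to a large group and meta to a trifluoromethyl group, the ring-free isobutoxy therefore gives a measurably lower number than 3-fluorophenyl, although compound 4 still reads in the low nanomolar range. Nothing at hand bears on what lies behind this difference.

Still open, going by these compounds, is how a plain phenyl would read against compound 4, which would separate the fluorine from the ring itself. Also open, on these data alone, is whether a longer alkoxy chain, a primary amine or a carboxylic acid on the same carbon would keep the number in this range.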